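From thiophen-3-yl to thiophen-2-yl on the shared core

A few compounds are considered here, and "the series" means these few. Any claim that something is new, unique, unknown or untested is made for them only; others in the source may bear on it.

In a functional assay on MDA-MB-468 cells (Homo sapiens) for cytotoxicity, read by resazurin assay, with a stated time of 72 h (on this read-out lower numbers stand for stronger inhibition and higher numbers for weaker inhibition), compound 1 `COc1ccc(-c2nnc(CCSC(=S)NCc3cccnc3)o2)cc1` gives 5220 nM and compound 2 `S=C(NCc1cccnc1)SCCc1nnc(-c2ccsc2)o1` gives 3260 nM. For the measured compounds named here, these are the only two numbers available, and they lie within the scatter of each other, so compound 2 cannot be set apart from compound 1.

Compound 3 `S=C(NCc1cccnc1)SCCc1nnc(-c2cccs2)o1` remains unmeasured. It has thiophen-2-yl in place of thiophen-3-yl on an aromatic carbon, and the two compounds have the same atoms, joined differently: thiophen-2-yl in place of thiophen-3-yl on an aromatic carbon.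

Going by the values given here, one measured step bears on this change, a 1.6-fold lower number from compound 1 to compound 2 (0.20 log units; within the scatter). It exchanged 4-methoxyphenyl for thiophen-3-yl on an aromatic carbon and stayed within the scatter. Among the compounds with values here, no measured step compares the two thiophene attachments directly, so the data offer no direction for this change. In this assay, no step beyond the scatter is expected. The estimated step is a 1.0-fold higher number from compound 2 to compound 3 (0.01 log units; within the scatter). Compound 3 is expected at 3300 nM, with an estimated range of 1500 nM to 7000 nM.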

Compound 3, half-maximal inhibitory concentration: 3410 nM
Compound 3: the middle estimate sits 1.0-fold (0.01 log units) below what was measured; the range from low to high includes it.
By their numbers in this assay, from the lowest: compounds 2, 3 and 1 (each within the scatter of the next).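

In this assay, for the compounds shown here, the change of attachment gives a 1.0-fold higher number from compound 2 to compound 3 (0.02 log units; within the scatter) and is the first direct comparison of the two thiophene attachments on an aromatic carbon of the five-membered aromatic ring with 2 nitrogen and 1 oxygen, so swapping thiophen-3-yl for its isomer thiophen-2-yl does not separate the two compounds here. The other new comparison, a 1.5-fold lower number from compound 1 to compound 3 (0.18 log units; within the scatter) for thiophen-2-yl in place of 4-methoxyphenyl, shows that thiophen-2-yl, like thiophen-3-yl, cannot be told apart from 4-methoxyphenyl, which leaves all three aromatic groups at this place within the scatter of one another in this cytotoxicity read-out. Nothing in the available material accounts for how closely these three compounds read.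

On these data alone, all three compounds carry an aromatic ring at this place, so what an amine, a carboxylic acid or a longer alkyl chain would do there remains open. The rest of the shared core is the same throughout, and the compounds shown therefore say nothing about how much a change elsewhere on it would matter.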